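Aryloxy-quinoline amines: permeability notes toward compound 4

A few compounds are considered here, and "the series" means these few. Any claim that something is new, unique, unknown or untested is made for them only; others in the source may bear on it.

Measured so far in an ADME assay for permeability, using PAMPA, with a stated time of 30 min, at pH 7.4; on this read-out higher numbers stand for higher permeability and lower numbers for lower permeability:
compound 1 `COc1ccc(Oc2ccc3c(NCCCNCc4cc(F)ccc4OC)ccnc3c2)cc1`, 317 10^-6 cm/s
compound 2 `c1ccc(Oc2ccc3c(NCCCNCc4ccco4)ccnc3c2)cc1`, 317 10^-6 cm/s
compound 3 `COc1ccc(Oc2ccc3c(NCCCNCc4cccc(OC)c4O)ccnc3c2)cc1`, 317 10^-6 cm/s

On these numbers compound 3 stands level with compound 1 and compound 2; the three read the same at the digits given. Within the data shown here, the one single-point step among them, no change at the digits printed from compound 1 to compound 3 (within the scatter), is within the scatter, so the swap of the aryl group on the saturated chain carbon bound to the amine nitrogen left this assay untouched.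

Compound 4 `COc1cccc(CNCCCNc2ccnc3cc(Oc4ccc(F)cc4)ccc23)c1O` is the next case. Its change from compound 3 is fluoro in place of methoxy on an aromatic carbon, on the aromatic carbon that sits para to a large group, so that the 4-methoxyphenoxy arm becomes 4-fluorophenoxy. Among the measured compounds shown here, none of the measured steps touches this arm; compound 2 carries a plain phenoxy arm and its value is the same as that of compound 3, which is the only hint available. No step beyond the scatter is therefore expected in this assay, and the estimated step of no change at the digits printed from compound 3 to compound 4 (within the scatter) is taken as flat. Compound 4 is expected at 317 10^-6 cm/s, with a range of 160 10^-6 cm/s to 630 10^-6 cm/s.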

Compound 4, apparent permeability: 317 10^-6 cm/s
Compound 4: middle estimate and measured number agree at the digits printed; measured number inside the range.
By their numbers in this assay, from the lowest: compounds 1, 2, 3 and 4 (each within the scatter of the next).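

The 4-methoxyphenoxy arm now has a measured step of its own: in this assay, fluoro in place of methoxy gives no change at the digits printed from compound 3 to compound 4 (within the scatter), so this aromatic carbon, para to a large group, joins the aryl group on the chain as a site with a flat step. The change is a real reduction in what is counted, with methoxy (2 heavy atoms, 1 hydrogen-bond acceptor) leaving and fluoro (1 heavy atom, 0 hydrogen-bond acceptors) entering, and the read-out still shows no step beyond the scatter. No supporting measurement is available that could explain this flat result.

On these data alone, whether an amine or a carboxylic acid on this aromatic carbon would also leave this assay flat remains open. A longer chain in place of the saturated chain is equally open, as the compounds shown contain no step beyond the scatter.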